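Nitro for Bromo on the Carbonyl Phenyl of Compound 2

A few compounds are considered here, and "the series" means these few. Any claim that something is new, unique, unknown or untested is made for them only; others in the source may bear on it.

Compound 2 `O=C(/C=C/c1ccc(OCc2cn(Cc3cccc(Br)c3)nn2)cc1)c1ccc(Br)cc1` stands second highest of three numbers in a functional assay on MIA PaCa-2 cells (Homo sapiens) for inhibition, read by MTT assay, with a stated time of 48 h, tested at 10 uM (on this read-out lower numbers stand for less inhibition of growth and higher numbers for more inhibition of growth at the one concentration tested), where compound 2 gives 43%. Its nearest neighbour is compound 1 `O=C(/C=C/c1ccc(OCc2cn(Cc3ccccc3)nn2)cc1)c1ccc(Br)cc1`, which in this assay gives 44%; the step of a number 1 percentage points lower from compound 1 to compound 2 (within the scatter) is within the scatter. Compound 3 `O=C(/C=C/c1ccc(OCc2cn(Cc3ccc(F)cc3)nn2)cc1)c1ccc(Br)cc1` gives 32% in this assay, and the step of a number 11 percentage points lower from compound 2 to compound 3 (beyond the scatter) lies beyond the scatter, as does a number 12 percentage points lower from compound 1 to compound 3 (beyond the scatter).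

Compound 4 `O=C(/C=C/c1ccc(OCc2cn(Cc3cccc(Br)c3)nn2)cc1)c1ccc([N+](=O)[O-])cc1` differs from compound 2 in one place: nitro in place of bromo on an aromatic carbon. None of the three measured steps concerns this part of the shared core; all of them vary the group on the saturated chain carbon bound to an aromatic nitrogen, and there they move the number by little or by a modest amount. Among the measured compounds shown here, no measured step therefore bears directly on the change to compound 4, and its effect cannot be read from these data. The step from compound 2 to compound 4 is expected to be a number 1 percentage points lower from compound 2 to compound 4 (within the scatter), most likely within the scatter, with a wide range on either side. Compound 4 is estimated at 42% in this assay, between 25% and 60%.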

Compound 4, percent growth inhibition at one concentration: 21%
Compound 4: the middle estimate sits 21 percentage points above what was measured; the measured number lies below the stated range.
By their numbers in this assay, from the lowest: compound 4; then compound 3; then compounds 2 and 1 (each within the scatter of the next).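

The change from 4-bromophenyl to 4-nitrophenyl on the carbonyl gives a number 22 percentage points lower from compound 2 to compound 4 (beyond the scatter) in this assay, the only step shown at this end of the molecule. This position is therefore not indifferent to its group: the step is larger than any of those at the other end, the largest of which is a number 12 percentage points lower from compound 1 to compound 3 (beyond the scatter). Nothing measured here accounts for this step.

With only bromo and nitro shown on this aromatic carbon, a single step cannot tell whether the lower number is particular to nitro or would follow other replacements of bromo, such as an amine, a methoxy group or a carboxylic acid. As far as these compounds go, it also remains open whether nitro in place of bromo would move the number the same way in compound 1 and compound 3.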